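Halogen swap on the benzoyl ring: compound 3 to compound 4

This account rests on a few compounds, and the source may have more. Where it says the series, first, only, none or still open, it means among the compounds named here.

Measured in a functional assay on Ehrlich cells (Mus musculus) for cytotoxicity, read by MTT assay, with a stated time of 48 h; a higher number here means a weaker inhibitor, a lower number a stronger inhibitor:
compound 1, `Cc1ccc(OCC(=O)NNC(=O)c2cc3ccccc3oc2=O)c(C(=O)c2ccccc2Br)c1`: 8000 nM
compound 2, `Cc1ccc(OCC(=O)NNC(=O)c2cc3ccccc3oc2=O)c(C(=O)c2ccccc2)c1`: 78400 nM
compound 3, `Cc1ccc(OCC(=O)NNC(=O)c2cc3ccccc3oc2=O)c(C(=O)c2ccc(Cl)cc2)c1`: 56600 nM

Compound 3 holds the second highest of the three numbers; compound 2 is nearest, compound 1 furthest, as seen in a 1.4-fold lower number from compound 2 to compound 3 (0.14 log units; within the scatter) and a 7.1-fold higher number from compound 1 to compound 3 (0.85 log units; beyond the scatter).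

Compound 4, `Cc1ccc(OCC(=O)NNC(=O)c2cc3ccccc3oc2=O)c(C(=O)c2ccc(Br)cc2)c1`, differs from compound 3 by bromo in place of chloro on an aromatic carbon. Going by the values given here, no measured step swaps chloro for bromo at the same carbon. The step of a 1.4-fold lower number from compound 2 to compound 3 (0.14 log units; within the scatter) shows chloro entering at this place within the scatter; a 9.8-fold higher number from compound 1 to compound 2 (0.99 log units; beyond the scatter) concerns bromo at another aromatic carbon, and a 7.1-fold higher number from compound 1 to compound 3 (0.85 log units; beyond the scatter) changes position and halogen together. The expected step is a 1.1-fold lower number from compound 3 to compound 4 (0.05 log units; within the scatter), nothing beyond the scatter. Compound 4 is estimated at 50000 nM, range 18000 nM to 140000 nM.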

Compound 4, half-maximal inhibitory concentration: 87300 nM
Estimate against measurement, compound 4: 1.7-fold (0.24 log units) below; low and high end bracket the measured number.
By their numbers in this assay, from the lowest: compound 1; then compounds 3, 2 and 4 (each within the scatter of the next).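

In this assay, exchanging one halogen for the other at this place gives no readable change: a 1.5-fold higher number from compound 3 to compound 4 (0.19 log units; within the scatter). Nor does bromo differ from hydrogen here: a 1.1-fold higher number from compound 2 to compound 4 (0.05 log units; within the scatter). With bromine present in both compounds, the step of an 11-fold higher number from compound 1 to compound 4 (1.04 log units; beyond the scatter) shows that where bromo sits on the ring matters, and no measurement on hand explains this. Open, on these data alone, is whether an amine or a methoxy group at this place would leave this group of values. Also open, as far as these compounds go, is whether chloro at the bromo position of compound 1 would match compound 1.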